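This account rests on a few compounds, and the source may have more. Where it says the series, first, only, none or still open, it means among the compounds named here.

The study follows cytotoxicity in an ADME assay on Jurkat cells (Homo sapiens) for cytotoxicity, read by WST assay, with a stated time of 48 h (on this read-out lower numbers stand for higher toxicity in this test and higher numbers for lower toxicity in this test), across a small set of compounds sharing one core. Compound 1 `Cc1ccc(Nc2nc(-c3ccccc3)c(C#N)c(N3CCCCC3)n2)cc1` does not give a number in this assay but only the limit of the measurement, > 10000 nM. Compound 2 `N#Cc1c(NC2CCCCC2)nc(SCc2ccccc2)nc1-c1ccc(Cl)cc1` likewise reaches only the limit, reported as > 10000 nM. Compound 3 `COc1ccc(-c2nc(SCc3ccccc3)nc(NCc3cccs3)c2C#N)cc1` also stops at the limit of this assay, giving > 10000 nM. On the numbers shown, compound 3 therefore stands nowhere apart from the others, because of the limit of > 10000 nM in this assay, at which 3 of the 3 values shown sit. For the measured compounds named here, no pair of measured compounds differs in a single place, so no measured step in this assay can be described.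

The next compound, compound 4 `COc1ccc(-c2nc(SCc3ccccc3)nc(N3CCC(C(N)=O)CC3)c2C#N)cc1`, differs from compound 3 in one place: 4-carbamoylpiperidin-1-yl in place of ((thiophen-2-yl)methyl)amino on an aromatic carbon. Going by the values given here, since no step between measured compounds exists to point to, nothing in the data suggests a move in either direction beyond the usual scatter of this assay. The estimated step that the limit leaves unreadable from compound 3 to compound 4 is therefore expected to stay within that scatter. Compound 4 is expected to give about 15000 nM in this assay, with a range from 8000 nM to 50000 nM, and most likely again only a limit rather than a number.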

Compound 4, half-maximal cytotoxic concentration: > 10000 nM
Compound 4: only a limit was reported (the forecaster's own chance of this, stated with the estimate: 85%); the middle value lies beyond the limit too.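

For the compounds shown here, compound 3 and compound 4 both stop at a limit in this assay, so no step between them can be read: the limit of > 10000 nM in this assay, at which 4 of the 4 values shown sit. The compounds shown leave open how far any of them lies beyond that limit, and whether any change on the shared core would give an actual number in this assay.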